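From Chlorophenyl to Methyl Ester: An Expected Loss

A few compounds are considered here, and "the series" means these few. Any claim that something is new, unique, unknown or untested is made for them only; others in the source may bear on it.

Of the compounds shown here, two have been tested in an assay on isolated protein for inhibition of alpha-ketoglutarate-dependent dioxygenase alkB homolog 3 (Homo sapiens), read by polymerase chain reaction, with a stated time of 1 h; a higher number here means a weaker inhibitor, a lower number a stronger inhibitor. Compound 1, `Oc1c(-c2ccccc2)c(-c2ccccc2)nn1-c1nc2cc(Cl)ccc2[nH]1`, gives 2000 nM in this assay. Compound 2, `Cc1[nH]n(-c2nc3ccccc3[nH]2)c(=O)c1Cc1cccc(Cl)c1`, gives 540 nM in this assay, the lower of the two numbers; the gap between compound 1 and compound 2 lies beyond the usual scatter, so compound 2 is the stronger inhibitor of the pair.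

Compound 3, `COC(=O)Cc1c(C)[nH]n(-c2nc3ccccc3[nH]2)c1=O`, has not yet been measured. It differs from compound 2 in one place: methoxycarbonyl in place of 3-chlorophenyl on a saturated chain carbon bound to an aromatic carbon. Among the compounds with values here, a whole aromatic ring leaves and a small ester takes its place; no measured pair shows what such a change does here, so the direction must be guessed from the size of what is lost. The step from compound 2 to compound 3 is expected to weaken inhibition clearly, by about a 5.6-fold higher number from compound 2 to compound 3 (0.74 log units; beyond the scatter). Compound 3 is therefore estimated at 3000 nM in this assay, plausibly between 800 nM and 12000 nM.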

Compound 3, half-maximal inhibitory concentration: 4300 nM
Beside the measured number, compound 3's estimate is 1.4-fold (0.16 log units) below it; low and high end bracket the measured number.
By their numbers in this assay, from the lowest: compound 2; then compound 1; then compound 3.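

In this assay, putting methoxycarbonyl in place of 3-chlorophenyl on a saturated chain carbon bound to an aromatic carbon gives an 8.0-fold higher number from compound 2 to compound 3 (0.90 log units; beyond the scatter), so inhibition clearly depends on what this position carries. Within the data shown here, this is the first measured step at this place, and it shows that a small ester with hydrogen-bond acceptors does not hold the inhibition seen with the chlorinated aromatic ring. The data offer no independent measurement that would explain this loss.

Among these compounds, with only this one change, it remains open whether the aromatic ring or its chlorine counts for more. A plain phenyl group, a carboxylic acid or an amide at this place could help separate the effect of ring size from that of the ester itself.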